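Swapping the amide substituent of a chromene carboxamide

The compounds below may be only part of what the source reports. "The series", "measured", "known", "first", "only" and "open" are said of these compounds alone.

Compound 1 has the structure `COc1ccc2c(c1)OC(c1cc(OC)c(OC)c(OC)c1)C(C(=O)Nc1ccccc1)=C2`. Among the measured compounds shown here, in a functional assay for inhibition of nuclear factor NF-kappa-B complex (Homo sapiens) (a higher number here means a weaker inhibitor, a lower number a stronger inhibitor), compound 1 gives 17500 nM, the only numerical value recorded here. Compound 2, with the structure `COc1ccc2c(c1)OC(c1cc(OC)c(OC)c(OC)c1)C(C(=O)NC(C)C)=C2`, differs from it by an isopropyl in place of phenyl on an amide-type nitrogen. In this assay compound 2 reaches only a limit, > 50000 nM. That change is an at least 2.8-fold higher number from compound 1 to compound 2 (0.45 log units; beyond the scatter), shown by the limit of > 50000 nM in this assay, at which 1 of the 2 values shown sits.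

Compound 3, with the structure `COc1ccc2c(c1)OC(c1cc(OC)c(OC)c(OC)c1)C(C(=O)N(C)C)=C2`, is not yet measured. It differs from compound 1 by dimethylamino in place of anilino on a carbonyl carbon. For the measured compounds named here, the only comparable change, from phenyl to a small alkyl group on the amide nitrogen, weakened inhibition, and a dimethylamino in place of anilino likewise replaces the ring with small alkyl groups. The step from compound 1 to compound 3 in this assay is therefore expected to be a 2.9-fold higher number from compound 1 to compound 3 (0.46 log units; beyond the scatter), towards weaker inhibition. Compound 3 is estimated at 50000 nM, likely between 20000 nM and 150000 nM, and may well appear only as a limit.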

Compound 3, half-maximal inhibitory concentration: > 50000 nM
Compound 3: only a limit was reported; the forecaster's own chance of this, stated with the estimate: 60%; the middle value lies on the limit itself.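

In this assay, compound 3 gives > 50000 nM, which is a limit of the assay and not a number. Dimethylamino in place of anilino is an at least 2.8-fold higher number from compound 1 to compound 3 (0.45 log units; beyond the scatter), so a second small group without the ring, this one also lacking the amide hydrogen, ends up on the same weak side as compound 2. The step between compound 2 and compound 3 cannot be read, so the effect of losing the amide hydrogen alone stays hidden, because both compounds sit at the limit: the limit of > 50000 nM in this assay, at which 2 of the 3 values shown sit.

Still open, from the compounds shown here alone, is whether the aromatic ring itself matters, or whether a non-aromatic ring such as cyclohexyl on the amide nitrogen would serve as well. An N-methylanilino group would keep the ring without the amide hydrogen and so separate the two changes.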